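Urea series, melting-temperature shift: trifluoromethyl to trifluoromethoxy

The source may hold more compounds than are shown below. What is called first, only, known or untested is meant among the compounds shown, and "the series" means these compounds.

Measured so far:
compound 1 `Cc1ccc(S(=O)(=O)NC(=O)Nc2cc(C(C)(C)C)nn2-c2ccccc2)cc1` gives -0.9 degrees C
compound 2 `CC(C)(C)c1cc(NC(=O)Nc2cc(F)cc(F)c2)n(-c2ccc(F)cc2)n1` gives 1.7 degrees C
compound 3 `CC(C)(C)c1cc(NC(=O)Nc2ccc(Cl)cc2)n(-c2ccc(C(F)(F)F)cc2)n1` gives -0.6 degrees C

All three numbers come from an assay on isolated protein for inhibition of serine/threonine-protein kinase 10 (Homo sapiens), read by thermal shift assay, tested at 10 uM; on this read-out lower numbers stand for weaker stabilisation of the target and higher numbers for stronger stabilisation of the target against heat. Among them, compound 3 sits in the middle of the three. Its number and that of compound 1 lie within the scatter of each other, so no order between those two can be read. Within the data shown here, compound 2 lies beyond the scatter above compound 3, and is the only number of the three that stands clearly apart from the other two.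

The next compound, compound 4 `CC(C)(C)c1cc(NC(=O)Nc2ccc(Cl)cc2)n(-c2ccc(OC(F)(F)F)cc2)n1`, keeps everything of compound 3 except one group: trifluoromethoxy in place of trifluoromethyl on an aromatic carbon. Among the measured compounds shown here, no pair of measured compounds shows this change, so nothing in the numbers tells how large its effect is. The measured compounds together span only a narrow band in this assay, and the change itself is small in atom count. A step within the scatter, in either direction, is expected. The step from compound 3 to compound 4 is estimated at a number 0.20 degrees C higher from compound 3 to compound 4 (within the scatter). Compound 4 is expected to give -0.4 degrees C, with a range from -1.8 degrees C to 1.2 degrees C.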

Compound 4, shift of the target's melting temperature: 0 degrees C
For compound 4 the middle estimate is 0.40 degrees C below the measured one, and the stated range covers the measured number.
By their numbers in this assay, from the lowest: compounds 1, 3 and 4 (each within the scatter of the next); then compound 2.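

Working notes on the position para to a large group: in this assay, the first measured pair here gives a number 0.60 degrees C higher from compound 3 to compound 4 (within the scatter) for trifluoromethoxy in place of trifluoromethyl on an aromatic carbon. Compound 3 and compound 4 therefore cannot be told apart on this read-out, and at this position, the exchange leaves no readable effect on stabilisation of the target. Nothing measured alongside these compounds offers an explanation for this step.

Still open, from the compounds shown here alone, is whether an amine, a carboxylic acid or a longer alkyl chain on this same carbon would give a step beyond the scatter. Also open, going by these compounds, is whether the same exchange gives a comparable step when the chlorophenyl group on the urea is replaced by another aryl group.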